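From Hydroxymethyl to Fluoromethyl on a Shared Core

This account rests on a few compounds, and the source may have more. Where it says the series, first, only, none or still open, it means among the compounds named here.

Compound 1, `COc1cc(C(c2ccc(O)c(OC)c2)[C@@H](C)[C@@H](C)CO)ccc1O`, in a functional assay on HeLa cells (Homo sapiens) for cytotoxicity, read by WST assay, with a stated time of 48 h; a higher number here means a weaker inhibitor, a lower number a stronger inhibitor: > 100000 nM, which is a limit of the assay, not a number.
Compound 2, `COC[C@@H](C)[C@H](C)C(c1ccc(O)c(OC)c1)c1ccc(O)c(OC)c1`: 58000 nM.

Compound 1 sits at the limit (the limit of > 100000 nM in this assay, at which 1 of the 2 values shown sits). Compound 3, `COc1cc(C(c2ccc(O)c(OC)c2)[C@@H](CF)C(C)C)ccc1O`, differs from compound 1 by 1-(fluoromethyl)-2-methylpropyl in place of 2-(hydroxymethyl)-1-methylpropyl on a saturated chain carbon bound to two aromatic carbons. Going by the values given here, one measured step bears on this: an at least 1.7-fold lower number from compound 1 to compound 2 (0.23 log units; that floor lies within the scatter). That change also removed the hydroxyl group from the side chain, so a comparably small lowering is expected here, possibly within the scatter. The step expected is an at least 1.6-fold lower number from compound 1 to compound 3 (0.22 log units; that floor lies within the scatter). Compound 3 is therefore estimated at 60000 nM, between 20000 nM and 150000 nM.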

Compound 3, half-maximal inhibitory concentration: 41000 nM
For compound 3 the middle estimate is 1.5-fold (0.17 log units) above the measured one; the range from low to high includes it.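

Putting 1-(fluoromethyl)-2-methylpropyl in place of 2-(hydroxymethyl)-1-methylpropyl gives a step that clears the scatter, which the methoxymethyl change did not: an at least 2.4-fold lower number from compound 1 to compound 3 (0.38 log units; beyond the scatter). The fluoromethyl and methoxymethyl chains cannot be told apart, however, with a 1.4-fold lower number from compound 2 to compound 3 (0.15 log units; within the scatter). The value of compound 1 is a limit and not a number, so the true size of its step stays unknown: the limit of > 100000 nM in this assay, at which 1 of the 3 values shown sits.

The two chains differ in more than fluorine against hydroxyl, and the compounds shown do not separate those differences. From the compounds shown here alone, it also remains open what an amine or a carboxylic acid on this chain would give.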